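Pyrido-fused core: benzyl amine without the methylsulfanyl substituent

This account rests on a few compounds, and the source may have more. Where it says the series, first, only, none or still open, it means among the compounds named here.

Measured so far:
compound 1, `CSc1ccc(CNc2nc(SC)nc3ncccc23)cc1`: 16800 nM in a functional assay on CCRF-CEM cells (Homo sapiens) for cytotoxicity, read by MTT assay, with a stated time of 72 h; a lower number here means a stronger inhibitor of growth, a higher number a weaker inhibitor of growth
compound 2, `[SeH]c1nc(NCc2ccccc2)c2ccccc2n1`: > 100000 nM in this assay, a limit of the assay, not a number
compound 3, `CSc1nc(NCCCCc2ccccc2)c2ccccc2n1`: > 100000 nM in this assay, likewise a limit of the assay

Within the data shown here, compound 1 holds the only number among the three values; the other two sit at the limit of > 100000 nM in this assay, at which 2 of the 3 values shown sit. Among the measured compounds shown here, compound 2 and compound 3 also carry different cores, so no single-point step between measured compounds exists, and nothing connects them to compound 1 by one change.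

Compound 4, `CSc1nc(NCc2ccccc2)c2cccnc2n1`, keeps the core of compound 1 and differs from it in one place: hydrogen in place of methylsulfanyl on an aromatic carbon. For the measured compounds named here, with no measured step of this kind to lean on, the change from compound 1 to compound 4 is expected to stay modest in this assay, more likely toward weaker growth inhibition than stronger, and possibly within the scatter; the estimate implies a 1.8-fold higher number from compound 1 to compound 4 (0.25 log units; within the scatter). Compound 4 is accordingly estimated at 30000 nM, with a range from 8000 nM to 100000 nM.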

Compound 4, concentration for total growth inhibition: 98600 nM
Estimate against measurement, compound 4: 3.3-fold (0.52 log units) below; the range from low to high includes it.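

Among these compounds, on the shared core, the methylsulfanyl group para to a large group gives the first single-place comparison in this assay: hydrogen in its place gives a 5.9-fold higher number from compound 1 to compound 4 (0.77 log units; beyond the scatter). The step lies beyond the scatter, so this position is not neutral for growth inhibition, at least between these two groups, and compound 4, at 98600 nM, leaves little readable room for further loss. Compound 2 and compound 3 each sit at a limit of the assay, not a number: the limit of > 100000 nM in this assay, at which 2 of the 4 values shown sit.

Among the compounds shown, this position carries only methylsulfanyl or hydrogen, so it remains open whether a methoxy group, a chlorine atom or an amine there would match compound 1 or improve on it. Going by these compounds, whether the same replacement has a comparable effect on the core of compound 3 also remains open.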